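Compound 4: trifluoromethyl in place of chloro

The source may report more compounds than this note shows. Statements on the series, on what has been measured and on what is new or still open speak of the compounds shown alone.

Measured so far in a functional assay on GLC82 cells (Homo sapiens) for cytotoxicity, read by MTT assay, with a stated time of 72 h; on this read-out lower numbers stand for stronger inhibition and higher numbers for weaker inhibition:
- compound 1, `COc1cc2ncnc(NNC(=S)NC(=O)c3ccc(Cl)cc3)c2cc1OC`: 9620 nM
- compound 2, `COc1ccccc1C(=O)NC(=S)NNc1ncnc2ccccc12`: 9500 nM
- compound 3, `O=C(NC(=S)NNc1ncnc2ccccc12)c1ccccc1`: 8370 nM

Compound 1 carries the nominally highest of the three numbers, but its gaps to compound 2 and to compound 3 are both within the scatter, so the three compounds cannot be told apart on this read-out. For the measured compounds named here, the only single-point comparison among them, a 1.1-fold lower number from compound 2 to compound 3 (0.05 log units; within the scatter), concerns a substituent on a different ring and is itself within the scatter.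

Compound 4, `COc1cc2ncnc(NNC(=S)NC(=O)c3ccc(C(F)(F)F)cc3)c2cc1OC`, differs from compound 1 in one place: trifluoromethyl in place of chloro on an aromatic carbon. Going by the values given here, no measured pair touches this position or this exchange, so nothing here bears directly on the step. What the three measured compounds do show is a flat read-out across a changed methoxy pattern on the core and a changed substituent on the other ring, with every number close to the others.

On that basis compound 4 is expected to land near compound 1, with a 1.1-fold lower number from compound 1 to compound 4 (0.03 log units; within the scatter) as the estimated step and no movement beyond the scatter anticipated. The estimate for compound 4 is 9000 nM, with a range from 4000 nM to 25000 nM.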

Compound 4, half-maximal inhibitory concentration: 16500 nM
The estimate for compound 4 lay 1.8-fold (0.26 log units) below the measured number; low and high end bracket the measured number.
By their numbers in this assay, from the lowest: compounds 3, 2, 1 and 4 (each within the scatter of the next).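

In this assay, the first step read at this position, on an aromatic carbon para to a large group, is a 1.7-fold higher number from compound 1 to compound 4 (0.23 log units; within the scatter), and it lies within the scatter. For the compounds shown here, the 4-chlorophenyl to 4-(trifluoromethyl)phenyl exchange therefore replaces a substituent of 1 heavy atom with one of 4 heavy atoms, neither with hydrogen-bond donors or acceptors, without a change that can be separated from the scatter; the earlier compounds offered no comparison at this position, and this single pair on the core of compound 1 now extends the flat picture to it. No available data indicate what lies behind the nominal gap between the two numbers, and no property of either group has been measured here.

Still open, from the compounds shown here alone, is whether any group at this position can move the number beyond the scatter, in particular a group of a different kind such as an amine, a carboxylic acid or a longer alkyl chain. Also open, going by these compounds, is whether trifluoromethyl in place of chloro would give a similar step on a core without the two methoxy groups, or at another carbon of the same aromatic ring.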